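Three Bicyclic Ethers and an Unspecified Fourth

The compounds below may be only part of what the source reports. "The series", "measured", "known", "first", "only" and "open" are said of these compounds alone.

Compound 1 `CC(C)(C)OC(=O)N1CC2CC1CC2Oc1ncnc(Nc2ccc(S(C)(=O)=O)cc2F)c1[N+](=O)[O-]`: 86.7%
Compound 2 `CC(C)(C)OC(=O)N1C[C@@H]2CC[C@@H]1C[C@@H]2Oc1ncnc(Nc2ccc(S(C)(=O)=O)cc2F)c1[N+](=O)[O-]`: 112%
Compound 3 `CC(C)(C)OC(=O)N1CC2CCC1CC2Oc1ncnc(Nc2ccc(S(C)(=O)=O)cc2)c1[N+](=O)[O-]`: 44.7%; 71.9% (2 entries)

In a functional assay on HEK293 cells for agonist activity at Glucose-dependent insulinotropic receptor (Homo sapiens), read by TR-FRET and cAMP accumulation, with a stated time of 60 min (on this read-out lower numbers stand for smaller maximal responses and higher numbers for larger maximal responses), compound 2 gives 112%, the higher of the two single numbers recorded there; the nearest, compound 1, lies a good way lower, beyond the usual scatter. Compound 3 has no single number, only two separate entries (the several entries of compound 3 in this assay, 44.7%; 71.9% (2 entries)), which spread widely and sit below compound 2.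

Compound 4 `CC(C)(C)OC(=O)N1CC2CCC1CC2Oc1ncnc(Nc2ccc(S(C)(=O)=O)cc2F)c1[N+](=O)[O-]` has not yet been measured. Compared with compound 2, (the two compounds have the same atoms and bonds; at least one stereo element is drawn with a configuration in one of them and without one in the other: 3 of 3 stereo elements differ; a stereocentre at a saturated ring carbon is drawn S in compound 2 and without a configuration in compound 4; a stereocentre at a saturated ring carbon is drawn R in compound 2 and without a configuration in compound 4; a stereocentre at a saturated ring carbon is drawn S in compound 2 and without a configuration in compound 4). Within the data shown here, no pair of measured compounds shows a step of this kind, so its size cannot be read from the data. Since compound 4 shares every atom and bond with compound 2, the step of a number 17 percentage points lower from compound 2 to compound 4 (beyond the scatter) is expected to be small, likely downward, and may well stay within the scatter; the scatter between the two entries of compound 3 is a reminder that repeated runs vary. The estimate for compound 4 in this assay is 95%, with a range from 65% to 120%.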

Compound 4, largest response reached (reported as percent of maximum), in percent of the reference or control that the assay uses: 32.9%
Estimate against measurement, compound 4: 62.1 percentage points above, and the stated range ends above it.
By their numbers in this assay, from the lowest: compound 4; then compound 1; then compound 2.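

In this assay, a change with no atom or bond altered comes with a number 79.1 percentage points lower from compound 2 to compound 4 (beyond the scatter) and so gives the first sign that the response at this receptor depends strongly on how the three saturated ring carbons are drawn. The earlier compounds shown here offered no step of this kind, and the only structural difference available to go with this one is: the fact that one of compounds 2 and 4 is drawn with a defined configuration and the other without, at the place where they differ. The step lies beyond the usual scatter, though repeat entries in this series can spread widely: the several entries of compound 3 in this assay, 44.7%; 71.9% (2 entries).

Compound 4 is drawn without configurations, so the compounds shown do not tell which stereoisomer or mixture its value reflects. They also leave open whether the same dependence on configuration would hold with a free amine in place of the tert-butyl carbamate.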